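This account rests on a few compounds, and the source may have more. Where it says the series, first, only, none or still open, it means among the compounds named here.

Measured in a functional assay on HeLa cells (Homo sapiens) for inhibition, read by MTT assay, with a stated time of 48 h; on this read-out lower numbers stand for stronger inhibition of growth and higher numbers for weaker inhibition of growth:
- Compound 1 `COc1ccc2c(c1)c(C1CC(c3ccc(Br)cc3)=NN1C(=O)c1ccc(OC)nc1)cn2C`: > 10000 nM, a limit
- Compound 2 `COc1cccc(C2=NN(C(=O)c3ccc(C)nc3)C(c3cn(C)c4ccc(OC)cc34)C2)c1`: 34 nM

Among the measured compounds shown here, compound 2 holds the only actual number in this small set. Compound 3 `COc1cccc(C2=NN(C(=O)c3ccc(OC)nc3)C(c3cn(C)c4ccc(OC)cc34)C2)c1` has not yet been measured. It differs from compound 2 by methoxy in place of methyl on an aromatic carbon, turning 6-methylpyridin-3-yl into 6-methoxypyridin-3-yl. Compound 1 also carries the 6-methoxypyridin-3-yl group, and its > 10000 nM is a limit. Compound 1 differs from compound 3 elsewhere too, so it is only a weak guide. A moderate weakening in this assay is therefore expected, an estimated step of a 4.4-fold higher number from compound 2 to compound 3 (0.64 log units; beyond the scatter). For compound 3 the estimated value is 150 nM, with an expected range of 25 nM to 2000 nM.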

Compound 3, concentration for 50% growth inhibition: 340 nM
Compound 3: middle estimate off by 2.3-fold (0.36 log units), on the low side; the measured number falls inside the stated range.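

With the 3-methoxyphenyl group unchanged, methoxy in place of methyl on the aromatic carbon next to the ring nitrogen weakens growth inhibition in this assay, with a 10-fold higher number from compound 2 to compound 3 (1.00 log units; beyond the scatter). The 6-methoxypyridin-3-yl group still permits clear activity, as 3-methoxyphenyl in place of 4-bromophenyl gives an at least 29-fold lower number from compound 1 to compound 3 (1.46 log units; beyond the scatter). That step has no exact size, as the value of compound 1 is a limit: the limit of > 10000 nM in this assay, at which 1 of the 3 values shown sits.

On these data alone, whether an amine or an ethyl group at this position would match methyl stays open. So does whether the step from methyl to methoxy would keep its size with 4-bromophenyl in the molecule.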